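The source may hold more compounds than are shown below. What is called first, only, known or untested is meant among the compounds shown, and "the series" means these compounds.

Working notes on the series. Among the measured compounds shown here, compound 2 `COc1ccc(/C=C2/SC(N3CCC[C@H]3C(=O)Nc3ccc4ncnc(Nc5cccc(Cl)c5)c4c3)=NC2=O)cc1` holds the smallest number of the two measured so far in a functional assay on HepG2 cells (Homo sapiens) for antiproliferative activity, read by MTT assay; on this read-out lower numbers stand for stronger inhibition and higher numbers for weaker inhibition: compound 2 gives 19000 nM, and its only neighbour, compound 1 `O=C1N=C(N2CCC[C@H]2C(=O)Nc2ccc3ncnc(Nc4cccc(Cl)c4)c3c2)S/C1=C/c1ccccc1[N+](=O)[O-]`, gives 32500 nM; the step of a 1.7-fold lower number from compound 1 to compound 2 (0.23 log units; within the scatter) is within the scatter, so the two cannot be told apart on these values. Compound 3 `O=C1N=C(N2CCC[C@H]2C(=O)Nc2ccc3ncnc(Nc4cccc(Cl)c4)c3c2)S/C1=C/c1ccccc1Cl` differs from compound 2 in one place: 2-chlorophenyl in place of 4-methoxyphenyl on a double-bonded chain carbon bound to a double-bonded ring carbon. For the measured compounds named here, the single measured step that bears on this exchange is the earlier swap of the group on a double-bonded chain carbon bound to a double-bonded ring carbon, a 1.7-fold lower number from compound 1 to compound 2 (0.23 log units; within the scatter), which left the read-out essentially unchanged. For compound 3 the expected step in this assay is therefore a 1.2-fold higher number from compound 2 to compound 3 (0.06 log units; within the scatter), nothing beyond the scatter in either direction. Compound 3 is estimated at 22000 nM in this assay, with a range from 9000 nM to 55000 nM.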

Compound 3, half-maximal inhibitory concentration: 28100 nM
Beside the measured number, compound 3's estimate is 1.3-fold (0.11 log units) below it; measured number inside the range.
By their numbers in this assay, from the lowest: compounds 2, 3 and 1 (each within the scatter of the next).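

In this assay, 2-chlorophenyl in place of 4-methoxyphenyl on a double-bonded chain carbon bound to a double-bonded ring carbon gives a 1.5-fold higher number from compound 2 to compound 3 (0.17 log units; within the scatter) and chloro in place of nitro on an aromatic carbon gives a 1.2-fold lower number from compound 1 to compound 3 (0.06 log units; within the scatter) and so neither exchange can be told apart from the scatter. The earlier pair offered one exchange at this position, whereas three substituted phenyl groups now sit there with no printed step beyond the scatter, including a direct exchange of nitro for chloro. No measurement at hand accounts for these small steps.

Open, as far as these compounds go, is whether an amine or a carboxylic acid on the phenyl ring would give a step beyond the scatter at this position. Equally open, from the compounds shown here alone, is whether a longer chain in place of the phenyl ring would do so.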